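The source may report more compounds than this note shows. Statements on the series, on what has been measured and on what is new or still open speak of the compounds shown alone.

Two compounds of the series carry numbers in a functional assay on 8305C cells (Homo sapiens) for cytotoxicity, read by MTT assay, with a stated time of 24 h; a higher number here means a weaker inhibitor, a lower number a stronger inhibitor. Compound 1 `CN1O[C@@H](n2ccnn2)C[C@@H]1CO` gives 7960 nM in this assay. Compound 2 `CN1O[C@H](n2cc(-c3ccccc3)nn2)C[C@@H]1CO` gives 8760 nM in this assay, the highest of the two numbers; its nearest neighbour is compound 1, and the gap between them lies within the scatter, so no order can be read from the pair.

Compound 3 `CN1O[C@H](n2ccnn2)C[C@@H]1CO` is not yet measured. Relative to compound 2 the change is hydrogen in place of phenyl on an aromatic carbon. Among the compounds with values here, no step between measured compounds is known for this change. Because compound 1 shows 7960 nM without a phenyl and compound 2 shows 8760 nM with one, the phenyl is not seen to move the number beyond the scatter. The step of a 1.0-fold lower number from compound 2 to compound 3 (0.01 log units; within the scatter) is therefore expected to be none beyond the scatter. Compound 3 is expected at 8500 nM, with a range from 4000 nM to 18000 nM.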

Compound 3, half-maximal inhibitory concentration: 8130 nM
Beside the measured number, compound 3's estimate is 1.0-fold (0.02 log units) above it; the range from low to high includes it.
By their numbers in this assay, from the lowest: compounds 1, 3 and 2 (each within the scatter of the next).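

In this assay, the place on the aromatic carbon now has a direct one-place reading, hydrogen in place of phenyl: a 1.1-fold lower number from compound 2 to compound 3 (0.03 log units; within the scatter), so the two groups are not told apart there. The configuration at the saturated ring carbon also gets its first reading, a 1.0-fold higher number from compound 1 to compound 3 (0.01 log units; within the scatter), so the R and S drawings at this stereocentre are not told apart either. That second step isolates this one stereocentre from every other structural feature: the fact that compounds 1 and 3 differ only in the configuration as drawn

From the compounds shown here alone, whether another group on the same aromatic carbon, such as an amine, a carboxylic acid or a longer chain, gives a number beyond the scatter remains open. Also open, going by these compounds, is whether the other stereo element, drawn alike in compound 1 and compound 3, has any bearing on the number.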